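The compounds below may be only part of what the source reports. "The series", "measured", "known", "first", "only" and "open" are said of these compounds alone.

Of the compounds shown here, three have been read in an ADME assay on microsomes from liver (Homo sapiens) for metabolic stability, read by LC-MS, using NADPH, tested at 1 uM; on this read-out lower numbers stand for a shorter-lived compound and higher numbers for a longer-lived compound: compound 1 `Cc1nc2c(N)ncnc2n1[C@@H]1O[C@H](CN(C)C/C=C\CNC(=O)OC(C)C)[C@@H](O)[C@H]1O`, compound 2 `CCC(=O)NC/C=C\CN(C)C[C@H]1O[C@@H](n2cnc3c(N)ncnc32)[C@H](O)[C@@H]1O` and compound 3 `CC(=O)NC/C=C\CN(C)C[C@H]1O[C@@H](n2cnc3c(N)ncnc32)[C@H](OC(C)=O)[C@@H]1OC(C)=O`. Compound 1 gives > 1.5 h, which is a limit and not a number. Compound 2 gives > 1.5 h, again a limit. Compound 3 gives > 1.5 h, also a limit. Compound 3 therefore has no exact half-life and stands at the limit of > 1.5 h in this assay, at which 3 of the 3 values shown sit.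

Compound 4 `CCC(=O)NC/C=C\CN(C)C[C@H]1O[C@@H](n2cnc3c(N)ncnc32)[C@H](OC(C)=O)[C@@H]1OC(C)=O` comes from compound 3 by a single change, (methyl in place of hydrogen on a saturated chain carbon bound to a carbonyl carbon), which turns acetamido to propanoylamino. Among the measured compounds shown here, no measured pair of compounds shows what this change does. With compound 3 reading > 1.5 h, no step beyond the scatter is expected in this assay, in either direction. The expected step is a step that the limit leaves unreadable from compound 3 to compound 4, which stays within the usual scatter. For compound 4 the estimated half-life is 1.8 h, with an expected range of 1 h to 3.2 h, and the result may well be a limit once more.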

Compound 4, half-life: 1.25 h
Compound 4: the middle estimate sits 1.4-fold (0.16 log units) above what was measured; measured number inside the range.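

In this assay, methyl in place of hydrogen on a saturated chain carbon bound to a carbonyl carbon, which turns acetamido to propanoylamino, gives an at least 1.2-fold lower number from compound 3 to compound 4 (0.07 log units; that floor lies within the scatter). Among the compounds shown here, this is the first reading of the change, and the printed floor of the step does not show that this position matters for the half-life. Compound 4, at 1.25 h, is the only compound shown with an exact half-life. Compound 1, compound 2 and compound 3 remain at a limit: the limit of > 1.5 h in this assay, at which 3 of the 4 values shown sit.

From the compounds shown here alone, the full size of the step remains unknown, as the value for compound 3 is only a limit. Also open, going by these compounds, is how a longer chain such as butanoylamino, or an amine or a carboxylic acid on this saturated chain carbon, would read in this assay.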